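Swapping the dichlorophenoxy arm of compound 1 for a fluorophenoxy

The source may report more compounds than this note shows. Statements on the series, on what has been measured and on what is new or still open speak of the compounds shown alone.

Of the compounds shown here, three sharing one core have been measured in a functional assay on SNB-19 cells (Homo sapiens) for inhibition, read by sulforhodamine B assay, with a stated time of 48 h; a lower number here means a stronger inhibitor of growth, a higher number a weaker inhibitor of growth. Compound 1, `Nc1cc(N)c2nc(-c3ccccc3)c(Oc3ccc(Cl)c(Cl)c3)nc2c1`, gives 20900 nM. Compound 2, `CCOC(=O)[C@H](CCC(=O)O)NC(=O)c1ccc(Sc2nc3cc(N)cc(N)c3nc2-c2ccccc2)cc1`, gives 56200 nM. Compound 3, `COc1cc(CNc2nc3cc(N)cc(N)c3nc2-c2ccccc2)cc(OC)c1OC`, gives 7240 nM. On these numbers compound 1 stands second highest of the three: compound 2 lies above it by a margin beyond the scatter, and compound 3 lies below it by a margin also beyond the scatter, so compound 1 sits between a weaker and a stronger inhibitor of growth.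

Compound 4, `Nc1cc(N)c2nc(-c3ccccc3)c(Oc3ccc(F)cc3)nc2c1`, has not yet been measured in this assay. It differs from compound 1 in one place: 4-fluorophenyl in place of 3,4-dichlorophenyl on an oxygen on an aromatic ring. Both arms hang from the same oxygen on the core, and neither carries a hydrogen-bond donor or acceptor.

Among the compounds with values here, no pair of measured compounds differs only in this way, so there is no measured step to lean on. The change is small in what is counted, and the expectation is a modest step, if any, and more likely toward a weaker inhibitor of growth than a stronger one. Compound 4 is therefore expected to give 30000 nM, within a range of 10000 nM to 90000 nM, which amounts to an estimated step of a 1.4-fold higher number from compound 1 to compound 4 (0.16 log units; within the scatter) that may well fall inside the scatter.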

Compound 4, concentration for 50% growth inhibition: 17400 nM
For compound 4 the middle estimate is 1.7-fold (0.24 log units) above the measured one, and the stated range covers the measured number.
By their numbers in this assay, from the lowest: compound 3; then compounds 4 and 1 (each within the scatter of the next); then compound 2.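

In this assay, within the data shown here, the swap of 3,4-dichlorophenyl for 4-fluorophenyl on the oxygen gives the first one-place reading at this position, a 1.2-fold lower number from compound 1 to compound 4 (0.08 log units; within the scatter) and so the two compounds cannot be told apart. Among these compounds, for this pair, then, the arm can lose both chlorine atoms and take a single fluorine without a step that rises above the scatter, something the earlier compounds could not show because each differs from the others in more than one place. No other measurement bears on this pair, so what lies behind the two similar readings stays unknown.

The compounds shown leave open whether this position tolerates all arms alike, since an unsubstituted phenyl, a phenyl carrying an amine or a carboxylic acid, or a longer chain on the same oxygen does not appear among them. They also leave open whether the same swap would read the same way on a different link to the core, as compound 2 and compound 3 carry other arms as well as other links and offer no one-place comparison with compound 4.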